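A few compounds are considered here, and "the series" means these few. Any claim that something is new, unique, unknown or untested is made for them only; others in the source may bear on it.

Values in a functional assay on KB cells (Homo sapiens) for antiproliferative activity, read by sulforhodamine B assay, with a stated time of 3 days (a higher number here means that more compound is needed for the effect, a lower number that less compound is needed), so far
- compound 1 `CCC1=C(O)c2c(oc(-c3cccc(C)c3)cc2=O)C(CC)(CC)C1=O` gives 49.7 uM
- compound 2 `CCC1=C(O)c2c(oc(-c3ccc(C)c(F)c3)cc2=O)C(CC)(CC)C1=O` gives 28.1 uM

Compound 2 stands within the scatter of compound 1 on these numbers. Compound 3 (`CCC1=C(O)c2c(oc(-c3cc(C)c(C)cc3C)cc2=O)C(CC)(CC)C1=O`) differs from compound 2 by one change (2,4,5-trimethylphenyl in place of 3-fluoro-4-methylphenyl on an aromatic carbon) on the aromatic carbon next to the ring oxygen. Among the measured compounds shown here, the only measured step (a 1.8-fold lower number from compound 1 to compound 2 (0.25 log units; within the scatter)) alters the same substituent and stays within the scatter, and no measured compound carries 2,4,5-trimethylphenyl. No step beyond the scatter is therefore expected in this assay here. Compound 3 is expected at 30 uM with an estimated range from 12 uM to 70 uM as the working figure. The estimated step is small (a 1.1-fold higher number from compound 2 to compound 3 (0.03 log units; within the scatter)) in this series.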

Compound 3, concentration for half-maximal effect: 8.2 uM
Compound 3: the middle estimate sits 3.7-fold (0.56 log units) above what was measured; the whole stated range lies above it.
By their numbers in this assay, from the lowest: compound 3; then compounds 2 and 1 (each within the scatter of the next).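

On the aromatic carbon next to the ring oxygen, the aryl group can move the number in this assay beyond the scatter, which the step between compound 1 and compound 2 did not show. 2,4,5-Trimethylphenyl in place of 3-fluoro-4-methylphenyl gives (a 3.4-fold lower number from compound 2 to compound 3 (0.53 log units; beyond the scatter)), and in place of 3-methylphenyl it gives (a 6.1-fold lower number from compound 1 to compound 3 (0.78 log units; beyond the scatter)). Nothing available explains this result.

Which of the three methyl groups carries the lower number remains open. So does how this position would read with an amine or a carboxylic acid on the aryl ring.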